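This account rests on a few compounds, and the source may have more. Where it says the series, first, only, none or still open, it means among the compounds named here.

Measured in a functional assay on CCRF-CEM cells (Homo sapiens); a lower number here means that less compound is tolerated, a higher number that more compound is tolerated:
- compound 1 `CC(=O)NC1=CS(=O)(=O)O[C@@]12[C@@H](CO[Si](C)(C)C(C)(C)C)O[C@@H](n1cc(C)c(=O)n(C)c1=O)[C@@H]2O[Si](C)(C)C(C)(C)C`: 25700 nM
- compound 2 `Cc1cn([C@@H]2O[C@@H]3COC(=O)[C@]3(OS(C)(=O)=O)[C@H]2O)c(=O)[nH]c1=O`: 160000 nM

Compound 1 holds the lower of the two numbers, and the gap up to compound 2 lies beyond the scatter. Compound 3 `COC(=O)CC(=O)NC1=CS(=O)(=O)O[C@@]12[C@@H](CO[Si](C)(C)C(C)(C)C)O[C@@H](n1cc(C)c(=O)n(C)c1=O)[C@@H]2O[Si](C)(C)C(C)(C)C` keeps the core of compound 1 and carries one change, methoxycarbonyl in place of hydrogen on a saturated chain carbon bound to a carbonyl carbon. Within the data shown here, no measured pair shows this change, so the direction stays open, and no step beyond the scatter is expected in this assay. The estimated step of a 1.2-fold higher number from compound 1 to compound 3 (0.07 log units; within the scatter) is therefore small. Compound 3 is estimated at 30000 nM, with an expected range of 11000 nM to 85000 nM.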

Compound 3, half-maximal cytotoxic concentration: 29700 nM
Estimate against measurement, compound 3: 1.0-fold (0.00 log units) above; the range from low to high includes it.
By their numbers in this assay, from the lowest: compounds 1 and 3 (each within the scatter of the next); then compound 2.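

Among these compounds, this is the first measured pair for this change: in this assay, methoxycarbonyl in place of hydrogen on a saturated chain carbon bound to a carbonyl carbon gives a 1.2-fold higher number from compound 1 to compound 3 (0.06 log units; within the scatter). The assay therefore does not separate compound 1 from compound 3, and this position takes the four added heavy atoms with no step beyond the scatter. Nothing available accounts for this result.

On these data alone, whether an amine, a carboxylic acid or a longer chain at this position would also stay within the scatter remains open.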